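Adding a Methyl to the Aromatic Ring of Compound 3

This account rests on a few compounds, and the source may have more. Where it says the series, first, only, none or still open, it means among the compounds named here.

Three compounds have been measured in a functional assay on NCI-H460 cells (Homo sapiens) for cytotoxicity, read by sulforhodamine B assay; a higher number here means a weaker inhibitor of growth, a lower number a stronger inhibitor of growth:

Compound 1 `CC1=CC[C@@H]([C@@](C)(O)CCCC(C)(C)NC=S)CC1` gives 9250 nM.
Compound 2 `CC1=CC[C@@H]([C@@](C)(O)CCCC(C)(C)NC(=S)NN)CC1` gives 12800 nM.
Compound 3 `CC1=CC[C@@H]([C@@](C)(O)CCCC(C)(C)NC(=S)N/N=C\c2ccccc2)CC1` gives 38400 nM.

Compound 3 stands highest of the three numbers, that is, it is the weakest inhibitor of growth among them. Its distance from compound 2 is a 3.0-fold higher number from compound 2 to compound 3 (0.48 log units; beyond the scatter), and from compound 1 it is a 4.2-fold higher number from compound 1 to compound 3 (0.62 log units; beyond the scatter). Both of those steps built up the thiocarbonyl end of the shared core, and both raised the number modestly. The step from compound 1 to compound 2, a 1.4-fold higher number from compound 1 to compound 2 (0.14 log units; within the scatter), stayed within the scatter.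

Compound 4 `CC1=CC[C@@H]([C@@](C)(O)CCCC(C)(C)NC(=S)N/N=C\c2ccc(C)cc2)CC1` differs from compound 3 by methyl in place of hydrogen on an aromatic carbon; the place is on an aromatic carbon of a six-membered aromatic ring of carbon only, para to a large group. Within the data shown here, no measured step touches this ring: the steps on hand changed a thiocarbonyl carbon or an amide-type nitrogen, not an aromatic carbon. There is therefore no direct anchor for this change, and a single methyl is a small addition. The expectation is a step of a 1.0-fold higher number from compound 3 to compound 4 (0.02 log units; within the scatter), that is, nothing beyond the scatter in either direction.

The estimate for compound 4 in this assay is 40000 nM, with a range from 15000 nM to 100000 nM.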

Compound 4, concentration for 50% growth inhibition: 10100 nM
Compound 4: the middle estimate sits 4.0-fold (0.60 log units) above what was measured; the whole stated range lies above it.
By their numbers in this assay, from the lowest: compounds 1, 4 and 2 (each within the scatter of the next); then compound 3.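

In this assay, the aromatic ring of compound 3 proves to be a sensitive place: phenyl to 4-methylphenyl, a change of a single carbon, gives a 3.8-fold lower number from compound 3 to compound 4 (0.58 log units; beyond the scatter) and runs opposite to the steps that built up the thiocarbonyl end of the shared core. The larger group carrying the ring therefore does not always come with a higher number, since the comparison with the smaller amino end gives a 1.3-fold lower number from compound 2 to compound 4 (0.10 log units; within the scatter) and so shows no difference beyond the scatter, unlike the unsubstituted phenyl of compound 3. No measured evidence on hand accounts for this effect of the methyl.

Going by these compounds, with one substituent at one place on the ring, it remains open whether the effect belongs to methyl alone or would also appear with an ethyl, a methoxy group, a chlorine atom or a carboxylic acid in its place. On these data alone, it is equally open whether a methyl on another carbon of the ring would give a similar step, and whether the same change would hold in any assay beyond this one.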